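Methoxyphenyl in Place of Fluorophenyl on the Shared Core

The source may report more compounds than this note shows. Statements on the series, on what has been measured and on what is new or still open speak of the compounds shown alone.

Compound 3 `CN1CCC[C@@H]1Cn1nc(Cc2cccc(F)c2)c2ccccc2c1=O` gives 398 nM in an assay for binding affinity to Alpha-1B adrenergic receptor (Homo sapiens) (on this read-out lower numbers stand for stronger inhibition and higher numbers for weaker inhibition), the highest of the two numbers in hand. Compound 2 `CN1CCC[C@@H]1Cn1nc(CCc2ccccc2)c2ccccc2c1=O` gives 200 nM, and the step of a 2.0-fold higher number from compound 2 to compound 3 (0.30 log units; within the scatter) stays within the scatter. Compound 1 `CN1CCC[C@@H]1Cn1nc(Cc2ccc(C(C)(C)C)cc2)c2ccccc2c1=O` reaches only a limit of the assay, > 1990 nM, in this assay (the limit of > 1990 nM in this assay, at which 1 of the 3 values shown sits). Compound 4 `COc1ccc(Cc2nn(C[C@H]3CCCN3C)c(=O)c3ccccc23)cc1` is not yet measured; it differs from compound 3 by 4-methoxyphenyl in place of 3-fluorophenyl on a saturated chain carbon bound to an aromatic carbon. Among the compounds with values here, the one measured step at that position, from compound 2 to compound 3, was within the scatter, so no large move is expected in this assay. The limit seen for compound 1 the limit of > 1990 nM in this assay, at which 1 of the 3 values shown sits, leaves room for a somewhat weaker result. For compound 4 the estimate is 600 nM, from 250 nM to 1500 nM, a step of a 1.5-fold higher number from compound 3 to compound 4 (0.18 log units; within the scatter) expected to stay near the scatter.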

Compound 4, inhibition constant: 158 nM
Compound 4: middle estimate off by 3.8-fold (0.58 log units), on the high side; measured number below the stated range.
By their numbers in this assay, from the lowest: compounds 4, 2 and 3 (each within the scatter of the next, the first and the last beyond it). At a limit, above all of these: compound 1.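

At this position the group on the saturated chain carbon can move the number beyond the scatter: 4-methoxyphenyl in place of 3-fluorophenyl gives a 2.5-fold lower number from compound 3 to compound 4 (0.40 log units; beyond the scatter). 4-methoxyphenyl in place of benzyl gives a 1.3-fold lower number from compound 2 to compound 4 (0.10 log units; within the scatter), so these two groups are not told apart. Methoxy in place of tert-butyl on an aromatic carbon gives an at least 12-fold lower number from compound 1 to compound 4 (1.10 log units; beyond the scatter), a step that starts from a limit of the assay: the limit of > 1990 nM in this assay, at which 1 of the 4 values shown sits.

The compounds shown leave open whether the step to compound 4 follows the group's identity or its ring position, which a 3-methoxyphenyl or a 4-fluorophenyl group would separate. Going by these compounds, how an amine or a carboxylic acid on that ring would read also stays open.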